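Prenyloxy in place of trifluoroethoxy on a cyclopropane carbohydrazide

The source may report more compounds than this note shows. Statements on the series, on what has been measured and on what is new or still open speak of the compounds shown alone.

Measured compounds:
- compound 1, `O=C(NNc1nncc2ccccc12)C1CC1c1ccc(OCC(F)(F)F)cc1`: 29000 nM
- compound 2, `COc1ccc(C2CC2C(=O)NNC(=O)c2ccncc2)cc1`: "not determined" (no result reported)

In a functional assay on SK-MEL cells (Homo sapiens) for inhibition, read by MTT assay, with a stated time of 72 h (on this read-out higher numbers stand for weaker inhibition and lower numbers for stronger inhibition), compound 1 gives 29000 nM. Among the compounds with values here, this is the only number in the set: in this assay compound 2 gives "not determined" (no result reported), so compound 1 stands alone and cannot be ranked against anything. Within the data shown here, no step between measured compounds exists.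

Compound 3, `CC(C)=CCOc1ccc(C2CC2C(=O)NNc2nncc3ccccc23)cc1`, differs from compound 1 in one place: 2-methylprop-1-en-1-yl in place of trifluoromethyl on a saturated chain carbon bound to an oxygen on an aromatic ring. Among the measured compounds shown here, the data hold no pair that shows what such a change does to inhibition in this assay. For the measured compounds named here, with only one number to rest on, the step from compound 1 to compound 3 is expected to be small, in no fixed direction, and within the usual scatter; the expected step is a 1.2-fold lower number from compound 1 to compound 3 (0.06 log units; within the scatter). Compound 3 is therefore estimated at 25000 nM, with a range from 8000 nM to 80000 nM, reflecting that the starting value of compound 1 is weak and that a weak compound may also return only a limit rather than a number.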

Compound 3, half-maximal inhibitory concentration: 67000 nM
The estimate for compound 3 lay 2.7-fold (0.43 log units) below the measured number, and the stated range covers the measured number.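

Putting 2-methylprop-1-en-1-yl in place of trifluoromethyl, on a saturated chain carbon bound to an oxygen on an aromatic ring, gives in this assay a 2.3-fold higher number from compound 1 to compound 3 (0.36 log units; beyond the scatter), the first step the set allows, and it lies beyond the usual scatter. The position therefore responds to a change of group even when the size by heavy-atom count stays the same: both groups have 4 heavy atoms, no ring and no hydrogen-bond donors or acceptors, yet three fluorines and a carbon give way to four carbons and a double bond, and inhibition weakens modestly. No measurement at hand bears on why this step occurs.

This single step on one core leaves open whether the weakening follows the loss of the fluorines or the arrival of the double bond, a question that a saturated 3-methylbutyl chain or a plain ethyl group at the same oxygen would help to separate. Going by these compounds, it is also open whether an amine or a hydroxyl at the end of that chain would move the number in the other direction, and whether the same change would give a similar step on another core.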